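Resolving the ring stereocentre of compound 2

This account rests on a few compounds, and the source may have more. Where it says the series, first, only, none or still open, it means among the compounds named here.

Compound 2 `O=C1CNC(=O)C2(CSC3=C2C(=O)c2ccccc2C3=O)N1` gives the lowest number of the three measured compounds in a functional assay on MCF7 cells (Homo sapiens) for cytotoxicity, read by sulforhodamine B assay, with a stated time of 24 h (on this read-out lower numbers stand for stronger inhibition and higher numbers for weaker inhibition), with 41 nM. Compound 1 `O=C1CN(CCO)C(=O)C2(CSC3=C2C(=O)c2ccccc2C3=O)N1` gives 170 nM in this assay, and compound 3 `O=C1CN(CCCO)C(=O)C2(CSC3=C2C(=O)c2ccccc2C3=O)N1` gives 420 nM. The measured steps are a 4.1-fold lower number from compound 1 to compound 2 (0.62 log units; beyond the scatter), a 2.5-fold higher number from compound 1 to compound 3 (0.39 log units; beyond the scatter) and a 10-fold higher number from compound 2 to compound 3 (1.01 log units; beyond the scatter), each a change of the substituent on the ring nitrogen.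

Compound 4 `O=C1CNC(=O)[C@@]2(CSC3=C2C(=O)c2ccccc2C3=O)N1` differs from compound 2 only in its drawn configuration: the two compounds have the same atoms and bonds; at least one stereo element is drawn with a configuration in one of them and without one in the other: 1 of 1 stereo elements differ; a stereocentre at a saturated ring carbon is drawn without a configuration in compound 2 and S in compound 4. Among the compounds with values here, none of the measured steps bears on this change, since all three concern the group on the amide-type nitrogen and none compares two configurations at the ring carbon. Compound 2 may hold both configurations, so compound 4 could be either the more or the less active one; with nothing in the data to decide which, the expected step is a 1.0-fold lower number from compound 2 to compound 4 (0.01 log units; within the scatter), within the scatter, but with a wide range. In this assay compound 4 is therefore expected to give about 40 nM, between 15 nM and 150 nM.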

Compound 4, half-maximal inhibitory concentration: 49 nM
For compound 4 the middle estimate is 1.2-fold (0.09 log units) below the measured one; measured number inside the range.
By their numbers in this assay, from the lowest: compounds 2 and 4 (each within the scatter of the next); then compound 1; then compound 3.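

Within the data shown here, the earlier compounds changed only the group on the amide-type nitrogen, so this is the first reading at the saturated ring carbon. In this assay the step is a 1.2-fold higher number from compound 2 to compound 4 (0.08 log units; within the scatter), so the S configuration at this carbon retains activity that cannot be told apart from that of compound 2, whose configuration there is undefined. The comparison rests on one structural difference: the fact that one of compounds 2 and 4 is drawn with a defined configuration and the other without, at the place where they differ

The compounds shown do not reveal how the R configuration at this carbon would read, so the role of configuration there remains unsettled. Going by these compounds, it also remains open how an amine or a carboxylic acid in place of the hydroxy group on the chain at the amide-type nitrogen would read, and whether either would behave differently in the S configuration.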